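Working notes: side-chain change on compound 1

The source may hold more compounds than are shown below. What is called first, only, known or untested is meant among the compounds shown, and "the series" means these compounds.

Measured so far in an ADME assay on microsomes from liver (Homo sapiens) for metabolic stability, read by LC-MS, using NADPH, with stated times of 5 min and 30 min, tested at 1 uM (on this read-out higher numbers stand for fast clearance and lower numbers for slow clearance), are two compounds.
- compound 1 `Cc1nc(CO)ccc1-c1cnc(NCc2c(F)ccc3c2CCO3)c2cn[nH]c(=O)c12` gives 11 mL.min-1.g-1
- compound 2 `CN(C)Cc1ccc2c(c1)CN(c1cnc(NCc3c(F)ccc4c3CCO4)n3cnnc13)C2=O` gives 19 mL.min-1.g-1

Among the measured compounds shown here, compound 1 and compound 2 lie within the usual scatter of each other, so neither can be ranked and compound 1 stands level with the only other measured value. Compound 3 `Cc1nc(CN(C)C)ccc1-c1cnc(NCc2c(F)ccc3c2CCO3)c2cn[nH]c(=O)c12` differs from compound 1 in one place. The change dimethylamino in place of hydroxy on a saturated chain carbon bound to an aromatic carbon sits on a saturated chain carbon bound to an aromatic carbon. For the measured compounds named here, no step between measured compounds gives a size for this change, so the expectation is only tentative. In this assay a small rise is expected, of a size not clearly beyond the scatter. The expected step of a 1.6-fold higher number from compound 1 to compound 3 (0.21 log units; within the scatter) remains to be tested. For compound 3 the estimated value is 18 mL.min-1.g-1 with an expected range from 9 mL.min-1.g-1 to 36 mL.min-1.g-1 at this stage.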

Compound 3, intrinsic clearance in microsomes: 13 mL.min-1.g-1
Estimate against measurement, compound 3: 1.4-fold (0.14 log units) above; the measured number falls inside the stated range.
By their numbers in this assay, from the lowest: compounds 1, 3 and 2 (each within the scatter of the next).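

In this assay, the position on a saturated chain carbon bound to an aromatic carbon now has its first measured step: dimethylamino in place of hydroxy gives a 1.2-fold higher number from compound 1 to compound 3 (0.07 log units; within the scatter) and so does not separate the two compounds. On this core, the read-out therefore tolerates this exchange, which removes the 1 hydrogen-bond donor of hydroxy and brings in the 3 heavy atoms of dimethylamino, without a change beyond the scatter. No measurement shown here accounts for this outcome.

From the compounds shown here alone, whether a cyclic amine such as morpholine or a carboxylic acid on this carbon would also stay within the scatter remains open. Going by these compounds, a longer chain carrying the dimethylamino group is equally open, and this single step cannot show whether the same exchange would read alike on another core.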